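Cytotoxicity notes: swapping the benzyl substituent in compound 2

This account rests on a few compounds, and the source may have more. Where it says the series, first, only, none or still open, it means among the compounds named here.

Of the compounds shown here, three have been measured in an ADME assay on L6 cells (Rattus norvegicus) for cytotoxicity, read by resazurin assay, with a stated time of 70 h; a higher number here means a weaker inhibitor, a lower number a stronger inhibitor. The ester compound 1 `COc1cc(OC)cc(C(=O)Oc2ccc3ncccc3c2)c1` gives 200000 nM. The shared core carrying a benzyl group on the ring nitrogen appears in compound 2 `CC(=O)Oc1ccc2c(c1)C(C)=CC(C)(C)N2Cc1cccc(C#N)c1`, which gives 31000 nM, and in compound 3 `CC(=O)Oc1ccc2c(c1)C(C)=CC(C)(C)N2Cc1cccc(C(F)(F)F)c1`, which gives 27000 nM. Compound 2 therefore stands second highest of the three numbers: compound 1 gives a higher number, while compound 3 lies within the scatter of compound 2, as the step of a 1.1-fold lower number from compound 2 to compound 3 (0.06 log units; within the scatter) shows.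

Compound 4 `COc1ccc(CN2c3ccc(OC(C)=O)cc3C(C)=CC2(C)C)cc1` has not been measured in this assay. It differs from compound 2 as follows: 4-methoxyphenyl in place of 3-cyanophenyl on a saturated chain carbon bound to a nitrogen on an aromatic ring in a ring. Among the compounds with values here, the one measured step that bears on this position, trifluoromethyl in place of cyano on an aromatic carbon, changed nothing beyond the scatter from compound 2 to compound 3. A second swap of the substituent on the same benzyl ring is therefore expected to give a step of a 1.0-fold lower number from compound 2 to compound 4 (0.01 log units; within the scatter) that stays within the scatter. Compound 4 is accordingly estimated at 30000 nM, with a range from 12000 nM to 80000 nM.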

Compound 4, half-maximal inhibitory concentration: 15000 nM
Beside the measured number, compound 4's estimate is 2.0-fold (0.30 log units) above it, and the stated range covers the measured number.
By their numbers in this assay, from the lowest: compounds 4, 3 and 2 (each within the scatter of the next, the first and the last beyond it); then compound 1.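

Replacing 3-cyanophenyl with 4-methoxyphenyl on a saturated chain carbon bound to a nitrogen on an aromatic ring in a ring gives a 2.1-fold lower number from compound 2 to compound 4 (0.32 log units; beyond the scatter) in this assay. This shows that changes on this benzyl ring can move the number beyond the scatter, which the earlier swap from nitrile to trifluoromethyl did not do, although the step remains modest. Because 3-cyanophenyl and 4-methoxyphenyl differ both in the group and in its place on the phenyl ring, the two contributions cannot be separated here, and no available measurement explains the step.

Still open, on these data alone, is whether an amine or a carboxylic acid on the benzyl ring would move the number further in either direction. Also open, as far as these compounds go, is whether a longer chain between the ring nitrogen and the phenyl ring would leave this step intact.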